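The source may hold more compounds than are shown below. What is called first, only, known or untested is meant among the compounds shown, and "the series" means these compounds.

Values so far in a functional assay on U-251 cells (Homo sapiens) for inhibition, read by sulforhodamine B assay, with a stated time of 72 h (on this read-out higher numbers stand for an effect only at larger amounts of compound and lower numbers for an effect already at smaller amounts), as follows:
compound 1 `O=C(/C=C/c1ccc([N+](=O)[O-])o1)c1ccc(Br)cc1` (21400 nM)
compound 2 `O=C(/C=C/c1ccc([N+](=O)[O-])o1)c1ccc(I)cc1` (12500 nM)
compound 3 `CC(C)(C)c1ccc(C(=O)/C=C/c2ccc([N+](=O)[O-])o2)cc1` (44500 nM)

Compound 3 has the highest number of the three. Compound 4 `CCCCc1ccc(C(=O)/C=C/c2ccc([N+](=O)[O-])o2)cc1` carries butyl in place of tert-butyl on an aromatic carbon, para to a large group butyl in place of tert-butyl on an aromatic carbon and is otherwise unchanged. Among the compounds with values here, the steps that bear on this are a 2.1-fold higher number from compound 1 to compound 3 (0.32 log units; beyond the scatter) and a 3.6-fold higher number from compound 2 to compound 3 (0.55 log units; beyond the scatter), both modest, while a 1.7-fold lower number from compound 1 to compound 2 (0.23 log units; within the scatter) stays within the scatter. Within the data shown here, no measured compound carries butyl at this place, so the size remains uncertain. A modestly lower number is expected in this assay for the new compound. The expected move is a 1.6-fold lower number from compound 3 to compound 4 (0.22 log units; within the scatter) in this estimate. Compound 4 is estimated at 27000 nM with a range of 11000 nM to 60000 nM as expected bounds.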

Compound 4, half-maximal effective concentration: 3900 nM
Compound 4: the middle estimate sits 6.9-fold (0.84 log units) above what was measured; the measured number lies below the stated range.
By their numbers in this assay, from the lowest: compound 4; then compounds 2 and 1 (each within the scatter of the next); then compound 3.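

At this place, para to a large group, joining the same atoms differently matters more than any exchange seen so far: an 11-fold lower number from compound 3 to compound 4 (1.06 log units; beyond the scatter) in this assay is the largest step in the series. Butyl also improves on both halogens, with a 3.2-fold lower number from compound 2 to compound 4 (0.51 log units; beyond the scatter) and a 5.5-fold lower number from compound 1 to compound 4 (0.74 log units; beyond the scatter) in the same read-out, so compound 3 alone did not show what an alkyl group can do here. No measured evidence explains this difference. As far as these compounds go, whether a longer chain such as hexyl or a shorter one such as ethyl would lower the number further remains open, as does the effect of an amine at this place.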